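Acetoxymethyl for methoxycarbonyl: a small step expected

This account rests on a few compounds, and the source may have more. Where it says the series, first, only, none or still open, it means among the compounds named here.

In a functional assay on ZR-75-1 cells (Homo sapiens) for cytotoxicity, read by sulforhodamine B assay, with a stated time of 3 days (on this read-out lower numbers stand for an effect already at smaller amounts and higher numbers for an effect only at larger amounts of compound), compound 1 `COC(=O)c1c(C)coc1-c1ccc2c(c1OC)CCCC2(C)C` gives 34.5 uM as its reading, and compound 2 `Cc1coc(-c2ccc3c(c2O)CCCC3(C)C)c1CO` gives 25.5 uM as its reading. For the measured compounds named here, these two numbers lie within the usual scatter of each other, so compound 1 stands level with the only other compound measured so far. Going by the values given here, no measured pair isolates a single structural change, which leaves no measured step to serve as a guide.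

Compound 3 `COc1c(-c2occ(C)c2COC(C)=O)ccc2c1CCCC2(C)C` has not yet been measured. It differs from compound 1 by acetoxymethyl in place of methoxycarbonyl on an aromatic carbon on an aromatic carbon of a five-membered aromatic ring with 1 oxygen. The two measured compounds sit close together, and nothing in them points to a large move, so no shift beyond the scatter is expected in this assay for this change. The step expected is a 1.2-fold lower number from compound 1 to compound 3 (0.06 log units; within the scatter) and it is estimated to stay within the scatter. For compound 3 the estimated value is 30 uM with an expected range of 14 uM to 60 uM in this read-out.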

Compound 3, concentration for half-maximal effect: 15.5 uM
Estimate against measurement, compound 3: 1.9-fold (0.29 log units) above; measured number inside the range.
By their numbers in this assay, from the lowest: compounds 3, 2 and 1 (each within the scatter of the next, the first and the last beyond it).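

In this assay, for the compounds shown here, acetoxymethyl in place of methoxycarbonyl on an aromatic carbon of the five-membered aromatic ring with 1 oxygen gives a 2.2-fold lower number from compound 1 to compound 3 (0.35 log units; beyond the scatter), the first measured single change in this set; the step is modest but lies beyond the scatter. This position, next to the ring atom that bears a large group and next to the ring atom that bears a methyl group, therefore responds to a change of this kind, even though both groups have 2 hydrogen-bond acceptors, 0 hydrogen-bond donors and no net charge, so these shared counts do not by themselves fix the reading. Nothing measured here accounts for the size or the direction of the step.

The compounds shown leave open how an amine, a carboxylic acid or a longer chain would read at this position, and so whether the step from compound 1 to compound 3 is part of a wider trend or stands alone. They also leave open whether the same exchange would give a similar step on a core other than that of compound 1.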